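Compound 3 to compound 4: pyridin-4-yl exchanged for phenyl

The source may report more compounds than this note shows. Statements on the series, on what has been measured and on what is new or still open speak of the compounds shown alone.

Compound 3 (`CNC(=O)c1cc(C(=O)NC2CCC2)cn(Cc2ccncc2)c1=O`) gives >= 118 ug/mL in a physicochemical assay for solubility (a lower number here means a less soluble compound, a higher number a more soluble compound), as a limit, not a number. No measured value in the series is anything other than a limit, so its standing among the others cannot be read.

The next structure is compound 4 (`CNC(=O)c1cc(C(=O)NC2CCC2)cn(Cc2ccccc2)c1=O`), with phenyl in place of pyridin-4-yl on a saturated chain carbon bound to an aromatic nitrogen. The same difference reads as (pyridin-4-yl)methyl to benzyl.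

Two other compounds carry the benzyl that enters here. Compound 1 (`CNC(=O)c1cc(C(=O)NCCCC2CNCCO2)cn(Cc2ccccc2)c1=O`) gives >= 194 ug/mL as a limit in this assay too. Compound 2 (`CNC(=O)c1cc(C(=O)NC2CCOCC2)cn(Cc2ccccc2)c1=O`) gives >= 174 ug/mL as a limit as well.

Among the measured compounds shown here, the only measured step is a step that the two limits leave unreadable from compound 1 to compound 2 and it concerns an amide-type nitrogen, a different place from the present change. For the measured compounds named here, it therefore offers no size to carry over, and no measured step covers this exchange. A modest fall is expected, held loosely, with a wide range.

The estimated step is an at least 1.2-fold lower number from compound 3 to compound 4 (0.09 log units; that floor lies within the scatter) and it points downward. Compound 4 is expected at 95 ug/mL with an estimated range from 35 ug/mL to 180 ug/mL and may also turn out to be only a limit.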

Compound 4, solubility: 28 ug/mL
For compound 4 the middle estimate is 3.4-fold (0.53 log units) above the measured one, and the stated range ends above it.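

In this assay, among the compounds shown here, the exchange of pyridin-4-yl for phenyl on a saturated chain carbon bound to an aromatic nitrogen gives an at least 4.2-fold lower number from compound 3 to compound 4 (0.62 log units; beyond the scatter), the first step whose direction can be read at this position. With benzyl held constant, the amide-type nitrogen also matters: cyclobutyl in place of oxan-4-yl gives an at least 6.2-fold lower number from compound 2 to compound 4 (0.79 log units; beyond the scatter), and cyclobutyl in place of 3-(morpholin-2-yl)propyl gives an at least 6.9-fold lower number from compound 1 to compound 4 (0.84 log units; beyond the scatter), so benzyl alone does not fix the low reading of compound 4. All three steps are floors and not full sizes, because the partner of compound 4 in each stands only as a limit, as for compound 3: the limit of >= 118 ug/mL in this assay, at which 1 of the 4 values shown sits.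

On these data alone, the true size of each step stays open, and the step from compound 1 to compound 2 cannot be read. Also open, as far as these compounds go, are whether the phenyl effect carries over to the oxan-4-yl or 3-(morpholin-2-yl)propyl amides, and how a carboxylic acid or an amine on the phenyl of compound 4 would read.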